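The source may hold more compounds than are shown below. What is called first, only, known or untested is meant among the compounds shown, and "the series" means these compounds.

Of the compounds shown here, three of a shared core have been measured so far. Compound 1 `CC1CCN(c2c(S(=O)(=O)c3ccc(Cl)cc3)cnc3ccc(F)cc23)CC1` gives 80% in an assay on isolated protein for displacement of a labelled ligand from metabotropic glutamate receptor 5 (Homo sapiens), with a stated time of 60 min, tested at 1 uM; a higher number here means more inhibition at the concentration tested (going by the name of the read-out), a lower number less inhibition. Compound 2 `Cc1ccc(S(=O)(=O)c2cnc3ccc(F)cc3c2N2CCC(C)CC2)cc1F` gives 86% in the same assay. Compound 3 `CC1CCN(c2c(S(=O)(=O)c3ccccc3)cnc3ccc(F)cc23)CC1` gives 40%, the lowest of the three numbers, sitting beyond the scatter under both of the others.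

The next compound, compound 4 `Cc1cc(C)cc(S(=O)(=O)c2cnc3ccc(F)cc3c2N2CCC(C)CC2)c1`, differs from compound 3 in one place: 3,5-dimethylphenyl in place of phenyl on a sulfonyl sulfur.

Within the data shown here, two measured steps bear on this change, both of which end at the bare phenyl of compound 3. The step of a number 40 percentage points lower from compound 1 to compound 3 (beyond the scatter) removed a single substituent from the ring on the sulfonyl sulfur; the step of a number 46 percentage points lower from compound 2 to compound 3 (beyond the scatter) removed two. Each time the unsubstituted phenyl gave a far weaker read-out. Putting two methyl groups onto that ring is therefore expected to move compound 4 back upward by a large margin, an estimated step of a number 35 percentage points higher from compound 3 to compound 4 (beyond the scatter).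

For compound 4 the estimated inhibition is 75%, with a range from 50% to 92%.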

Compound 4, a percentage reported as inhibition, at one concentration (the size of the read-out at that concentration, not a potency): 83%
Beside the measured number, compound 4's estimate is 8 percentage points below it, within the range that was stated.
By their numbers in this assay, from the lowest: compound 3; then compounds 1, 4 and 2 (each within the scatter of the next).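

The step of a number 43 percentage points higher from compound 3 to compound 4 (beyond the scatter) in this assay shows that methyl groups alone can restore a large read-out at this position, with no chloro or fluoro group on the ring attached to the sulfonyl sulfur. The steps of a number 3 percentage points higher from compound 1 to compound 4 (within the scatter) and a number 3 percentage points lower from compound 2 to compound 4 (within the scatter) are both within the scatter, so this assay cannot separate 3,5-dimethylphenyl from either of the two halogen-bearing rings. No measurement here explains why these substituted rings differ so much from the bare phenyl.

As far as these compounds go, it remains open whether a phenyl ring with a single methyl group would be enough, or whether a methoxy group, a nitrile or an amine on that ring would give a similar read-out. From the compounds shown here alone, each number gives the size of the effect at one concentration only, so how compounds 1, 2 and 4 would compare at other concentrations also remains unknown.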